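This account rests on a few compounds, and the source may have more. Where it says the series, first, only, none or still open, it means among the compounds named here.

Measured so far in a functional assay on HepG2 cells (Homo sapiens) for inhibition, read by MTT assay, with a stated time of 24 h (on this read-out higher numbers stand for weaker inhibition of growth and lower numbers for stronger inhibition of growth), are two compounds:
Compound 1 `Cn1cc(-c2nc3ccccc3n2C(=O)c2cccc(Br)c2)c2ccccc21` gives 61400 nM
Compound 2 `COc1ccc(C(=O)n2c(-c3cn(C)c4ccc(Br)cc34)nc3ccccc32)cc1` gives 18900 nM

Compound 2, at 18900 nM and the lower of the two numbers, stands beyond the scatter from compound 1. The change to compound 3 `Cn1cc(-c2nc3ccccc3n2C(=O)c2cccc(Br)c2)c2cc(Br)ccc21` is 3-bromophenyl in place of 4-methoxyphenyl on a carbonyl carbon and puts 3-bromophenyl in place of 4-methoxyphenyl on a carbonyl carbon. For the measured compounds named here, no measured pair shows this change alone. Compound 1, which also carries 3-bromophenyl, gives 61400 nM and so suggests a small rise in this assay that stays within the scatter. The expected step is a 1.6-fold higher number from compound 2 to compound 3 (0.20 log units; within the scatter) and would mean slightly weaker inhibition of growth. For compound 3 the estimated value is 30000 nM within 11000 nM to 75000 nM as the expected range.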

Compound 3, concentration for 50% growth inhibition: 67300 nM
The estimate for compound 3 lay 2.2-fold (0.35 log units) below the measured number, within the range that was stated.
By their numbers in this assay, from the lowest: compound 2; then compounds 1 and 3 (each within the scatter of the next).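

In this assay, for the compounds shown here, the step to 3-bromophenyl in place of 4-methoxyphenyl on the carbonyl carbon is a 3.6-fold higher number from compound 2 to compound 3 (0.55 log units; beyond the scatter) and gives the first single-change reading at this position, towards weaker inhibition of growth. Bromo in place of hydrogen on an aromatic carbon gives a 1.1-fold higher number from compound 1 to compound 3 (0.04 log units; within the scatter) and so leaves the number unchanged within the scatter. Nothing available explains either step.

The compounds shown leave open whether the difference follows the methoxy group or the bromine. They also leave open how a phenyl bearing an amine or a carboxylic acid on this carbonyl carbon would read.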